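A Bromine Added to the Weakest Member of the Set

The source may report more compounds than this note shows. Statements on the series, on what has been measured and on what is new or still open speak of the compounds shown alone.

Of the compounds shown here, three share one core and have been tested in a functional assay on cells (Leukemia cell, Homo sapiens) for cytotoxicity, read by sulforhodamine B assay, with a stated time of 48 h; a lower number here means a stronger inhibitor of growth, a higher number a weaker inhibitor of growth. Compound 1 `COc1ccc(C2CC(c3ccccc3)=NN2C2=NC(=O)/C(=C3\C(=O)Nc4ccc(Br)cc43)S2)cc1` gives 250 nM, and compound 2 `COc1ccc(C2=NN(C3=NC(=O)/C(=C4\C(=O)Nc5ccc(Br)cc54)S3)C(c3ccc(OC)cc3)C2)cc1` gives 280 nM; the change between them, a 1.1-fold higher number from compound 1 to compound 2 (0.05 log units; within the scatter), leaves the number essentially where it was. Compound 3 `COc1ccc(C2CC(c3ccc4ccccc4c3)=NN2C2=NC(=O)/C(=C3\C(=O)Nc4ccccc43)S2)cc1` gives 17500 nM and is the weakest inhibitor of the three: its number stands far above those of compound 1 and compound 2, well beyond the scatter.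

Compound 4 `COc1ccc(C2CC(c3ccc4ccccc4c3)=NN2C2=NC(=O)/C(=C3\C(=O)Nc4ccc(Br)cc43)S2)cc1` is compound 3 with one alteration: bromo in place of hydrogen on an aromatic carbon. Among the measured compounds shown here, no measured step isolates this change. Compound 1 and compound 2 both carry the bromo group and both have low numbers, but each also differs from compound 3 in a second place, so their values only hint that the bromo group is compatible with strong inhibition. For the measured compounds named here, the one measured step, a 1.1-fold higher number from compound 1 to compound 2 (0.05 log units; within the scatter), concerns a different position and gives no guide here. The expectation for compound 4 is therefore a modest improvement, estimated as a 2.5-fold lower number from compound 3 to compound 4 (0.40 log units; beyond the scatter) in this assay, with wide uncertainty. Compound 4 is estimated to give 7000 nM in this assay, within a range from 1500 nM to 30000 nM.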

Compound 4, concentration for 50% growth inhibition: 130 nM
Estimate against measurement, compound 4: 54-fold (1.73 log units) above; the whole stated range lies above it.
By their numbers in this assay, from the lowest: compounds 4, 1 and 2 (each within the scatter of the next, the first and the last beyond it); then compound 3.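

In this assay, the step at this aromatic carbon, part of a fused or bridged system of two rings, can now be read directly: bromo in place of hydrogen gives a 130-fold lower number from compound 3 to compound 4 (2.13 log units; beyond the scatter) and is a large change from a single added atom. The group on the carbon with a double bond to nitrogen counts for far less once bromo is present, since naphthalen-2-yl in place of 4-methoxyphenyl gives only a 2.2-fold lower number from compound 2 to compound 4 (0.33 log units; beyond the scatter) and naphthalen-2-yl in place of phenyl gives a 1.9-fold lower number from compound 1 to compound 4 (0.28 log units; within the scatter) with no real change. The naphthalen-2-yl group is therefore compatible with a low number, and the high number of compound 3 goes with hydrogen at this position rather than with naphthalen-2-yl alone.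

Going by these compounds, only hydrogen and bromo appear at this position, so it remains open how chloro or an amine would behave there, and whether removing bromo costs as much when phenyl or 4-methoxyphenyl replaces naphthalen-2-yl. Nothing in the data explains the size of the bromo step.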